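Amide substituent series: from benzyl to 4-methylphenyl

The compounds below may be only part of what the source reports. "The series", "measured", "known", "first", "only" and "open" are said of these compounds alone.

Of the compounds shown here, two have been measured in a functional assay on the whole organism for inhibition, with Rattus norvegicus as the target, read by cytopathic effect and paw edema, at a dose of 100 mg/kg by the oral route; a higher number here means more inhibition at the dose given (going by the name of the read-out), a lower number less inhibition. Compound 1 `O=C(Nc1ccccn1)c1c(O)c2cccnc2n(-c2ccccc2)c1=O` carries a pyridin-2-yl group on the amide-type nitrogen, and in this assay compound 1 gives 14.6%. Compound 2 `O=C(NCc1ccccc1)c1c(O)c2cccnc2n(-c2ccccc2)c1=O` carries a benzyl group at the same place; in this assay compound 2 gives 11.3%. The step of a number 3.3 percentage points lower from compound 1 to compound 2 (within the scatter) is within the scatter, so the two values cannot be ordered. Within the data shown here, compound 2 thus stands within the scatter of the only other value known in this assay.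

Compound 3 `Cc1ccc(NC(=O)c2c(O)c3cccnc3n(-c3ccccc3)c2=O)cc1` is the next compound to be measured. It differs from compound 2 in one place: 4-methylphenyl in place of benzyl on an amide-type nitrogen. Among the measured compounds shown here, only one measured step bears on a change at this amide-type nitrogen, namely a number 3.3 percentage points lower from compound 1 to compound 2 (within the scatter), and that exchange of an aryl group for a benzyl group left the inhibition within the scatter. For the measured compounds named here, the present change is of a similar kind, a benzyl group giving way to an aryl group, and the sole reference step gives no reason to expect a step in this assay beyond the scatter. Compound 3 is therefore expected to give about 13%, with a range from 2% to 26%. The expected step is a number 1.7 percentage points higher from compound 2 to compound 3 (within the scatter), none beyond the scatter.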

Compound 3, a percentage reported as inhibition, in the whole organism at one dose (the size of the read-out at that dose, not a potency): 2.2%
For compound 3 the middle estimate is 10.8 percentage points above the measured one; the measured number falls inside the stated range.
By their numbers in this assay, from the lowest: compounds 3, 2 and 1 (each within the scatter of the next, the first and the last beyond it).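

The exchange of benzyl for 4-methylphenyl on the amide-type nitrogen gives, in this assay, a number 9.1 percentage points lower from compound 2 to compound 3 (within the scatter) and so cannot be told apart from no change at all. Among these compounds, this position is still not silent, since the exchange of pyridin-2-yl for 4-methylphenyl gives a number 12.4 percentage points lower from compound 1 to compound 3 (beyond the scatter) and is the only step at this nitrogen so far to pass the scatter, if only modestly. Two aryl groups on the same nitrogen can therefore be told apart in the whole animal while benzyl cannot be separated from either, so the aryl or benzyl type of attachment does not order these three compounds, and nothing at hand explains the gap between the two aryl amides.

Still open, as far as these compounds go, is whether that gap follows the methyl group or the ring nitrogen, which a plain phenyl or a pyridin-3-yl group on this nitrogen would help to separate. Also open, from the compounds shown here alone, is whether a longer chain such as phenethyl, or a carboxylic acid on the aryl ring, would move the inhibition beyond the scatter of all three compounds.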